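The source may hold more compounds than are shown below. What is called first, only, known or untested is meant among the compounds shown, and "the series" means these compounds.

Measured so far in a functional assay on HepG2 cells (Homo sapiens) for inhibition, read by MTT assay, with a stated time of 72 h; on this read-out lower numbers stand for stronger inhibition and higher numbers for weaker inhibition:
- compound 1 `COc1ccccc1NC(=O)C1CCN(C/C=C/c2ccccc2)CC1`: 91200 nM
- compound 2 `N#Cc1ccc(NC(=O)C2CCN(C/C=C/c3ccccc3)CC2)cc1`: 38300 nM

Compound 2, at 38300 nM, holds the lower of the two numbers, and compound 1 stands higher at 91200 nM. The next entry is compound 3 `O=C(Nc1ccccn1)C1CCN(C/C=C/c2ccccc2)CC1`, which puts pyridin-2-yl in place of 4-cyanophenyl on an amide-type nitrogen. Going by the values given here, one measured step bears on this place: a 2.4-fold lower number from compound 1 to compound 2 (0.38 log units; beyond the scatter). That step is modest, though beyond the usual scatter, and it shows that changing the group on this nitrogen has so far moved the number only a little. Among the compounds with values here, no measured compound carries pyridin-2-yl on this nitrogen, so the data do not fix a direction. A step of similar or smaller size is expected in this assay, leaning slightly towards a higher number. The expected step is a 1.6-fold higher number from compound 2 to compound 3 (0.19 log units; within the scatter). For compound 3 the estimated value is 60000 nM, with an expected range from 25000 nM to 130000 nM.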

Compound 3, half-maximal inhibitory concentration: 51100 nM
Estimate against measurement, compound 3: 1.2-fold (0.07 log units) above; the range from low to high includes it.
By their numbers in this assay, from the lowest: compounds 2, 3 and 1 (each within the scatter of the next, the first and the last beyond it).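

In this assay, the step of a 1.3-fold higher number from compound 2 to compound 3 (0.13 log units; within the scatter) and the step of a 1.8-fold lower number from compound 1 to compound 3 (0.25 log units; within the scatter) both lie within the scatter, so pyridin-2-yl on the amide-type nitrogen cannot be told apart from either 4-cyanophenyl or 2-methoxyphenyl. Going by these compounds alone, the earlier pair showed only that two carbon-only aromatic rings with different substituents could differ modestly; this result adds that a six-membered aromatic ring with a hetero atom, carrying fewer heavy atoms than 4-cyanophenyl, also keeps the number in the same region, and it adds no separation beyond the one already seen between the two earlier compounds. No measurement available here accounts for this flat response at the amide-type nitrogen.

The three compounds shown all carry a six-membered aromatic ring at this place, so it remains open whether a saturated group such as cyclohexyl, or an open chain such as a longer alkyl chain ending in an amine, would move the number further. On these data alone, it also remains open whether any change elsewhere on the shared core would produce a larger step than those seen on this nitrogen.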